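The source may report more compounds than this note shows. Statements on the series, on what has been measured and on what is new or still open speak of the compounds shown alone.

Working notes on the series in a functional assay on MCF7 cells (Homo sapiens) for cytotoxicity, read by MTT assay, with a stated time of 72 h; on this read-out higher numbers stand for weaker inhibition and lower numbers for stronger inhibition.

Compound 1 `COc1ccc(-n2ccc(=O)c(C(=O)Nc3ccc(Oc4ccnc5[nH]ccc45)cc3)n2)cc1` is the reference point with a numerical result: in this assay compound 1 gives 21600 nM. Compound 2 `Cn1ccc2c(Oc3ccc(NC(=O)c4nn(-c5ccc(Cl)cc5)ccc4=O)cc3)ccnc21` carries a 4-chlorophenyl and a methylated core. For compound 2 the assay reports only a limit, > 60000 nM, and no number; this is the limit of > 60000 nM in this assay, at which 1 of the 2 values shown sits. So compound 2 stands at the edge of what the assay resolves, and any step from it can only be read against that limit.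

Compound 3 `COc1ccc(-n2ccc(=O)c(C(=O)Nc3ccc(Oc4ccnc5c4ccn5C)cc3)n2)cc1` differs from compound 2 by one change: methoxy in place of chloro on an aromatic carbon. Among the measured compounds shown here, the methoxy group is the one present in compound 1, while the methylated core is the one present in compound 2, so compound 3 sits between the two measured compounds and no measured step covers this pair directly.

Expectation: a step of an at least 1.5-fold lower number from compound 2 to compound 3 (0.17 log units; that floor lies within the scatter) toward the stronger side is estimated, since compound 1 with the same methoxy group gives 21600 nM. For compound 3 the estimate is 40000 nM, in the range 15000 nM to 100000 nM.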

Compound 3, half-maximal inhibitory concentration: > 60000 nM
Compound 3: no number, only a limit; the forecaster's own chance of this, stated with the estimate: 40%; middle value at least 1.5-fold (0.17 log units) away from the limit.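

Among the compounds shown here, with the 4-methoxyphenyl held constant, methyl in place of hydrogen on an aromatic nitrogen gives the first readable step in this assay, an at least 2.7-fold higher number from compound 1 to compound 3 (0.44 log units; beyond the scatter). Compound 2 and compound 3 both stand at a limit of the assay rather than at a number, so the change from 4-chlorophenyl to 4-methoxyphenyl cannot be read on the methylated core. The methoxy group that comes with a numerical value in compound 1 therefore does not bring compound 3 into the measurable range, and the limit now accounts for most of the series: the limit of > 60000 nM in this assay, at which 2 of the 3 values shown sit.

The compounds shown leave open whether chloro and methoxy differ at all on the core of compound 1, where the read-out can return a number, and where compound 2 and compound 3 truly lie beyond the limit. They also leave open how a longer chain on that aromatic nitrogen, or an amine in place of methoxy on the aromatic ring, would read.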